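The source may hold more compounds than are shown below. What is called first, only, known or untested is meant among the compounds shown, and "the series" means these compounds.

Measured so far in a functional assay on HT cells (Homo sapiens) for antiproliferative activity, read by fluorescence, with a stated time of 72 h; a higher number here means a weaker inhibitor of growth, a lower number a stronger inhibitor of growth:
- compound 1 `CC(C)c1n[nH]c2c(NCc3ccc(-c4ccccn4)cc3)nc(SC3CCCCC3O)nc12`: 636 nM
- compound 2 `C=CCSc1nc(NCc2ccc(-c3ccccn3)cc2)c2[nH]nc(C(C)C)c2n1`: 1010 nM

Compound 2 has only compound 1 for comparison on these numbers, and the two lie within the scatter of each other. Still unmeasured is compound 3 `CCC(O)CSc1nc(NCc2ccc(-c3ccccn3)cc2)c2[nH]nc(C(C)C)c2n1` with 1-hydroxypropyl in place of vinyl on a saturated chain carbon bound to a sulfur and, read one bond further out, allyl to 2-hydroxybutyl. Going by the values given here, one measured step bears on this change: a 1.6-fold higher number from compound 1 to compound 2 (0.20 log units; within the scatter) for allyl in place of 2-hydroxycyclohexyl on a sulfur. Among the compounds with values here, a hydroxyl-bearing group and allyl in that place have therefore not been told apart in this assay so far. This rests on a single pair, whose hydroxyl-bearing group contains a ring, and no open-chain hydroxyl-bearing group has been measured. No shift beyond the scatter is expected. The expected step is a 1.3-fold lower number from compound 2 to compound 3 (0.10 log units; within the scatter) and it remains an estimate from one pair. For compound 3 the estimated value is 800 nM with an expected range from 350 nM to 1800 nM in this assay.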

Compound 3, concentration for 50% growth inhibition: 273 nM
The estimate for compound 3 lay 2.9-fold (0.47 log units) above the measured number, and the stated range ends above it.
By their numbers in this assay, from the lowest: compound 3; then compounds 1 and 2 (each within the scatter of the next).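

At the saturated chain carbon bound to a sulfur, this assay now separates a hydroxyl-bearing group from allyl, with a 3.7-fold lower number from compound 2 to compound 3 (0.57 log units; beyond the scatter) for the change from allyl to 2-hydroxybutyl, where the earlier pair had left the two groups unresolved. The open-chain 2-hydroxybutyl also separates from the ring-containing 2-hydroxycyclohexyl, with a 2.3-fold lower number from compound 1 to compound 3 (0.37 log units; beyond the scatter) for that exchange, so the presence of a hydroxyl does not by itself set the number at this place: compound 1 carries a hydroxyl and still lies within the scatter of the allyl compound 2. No measurement at hand accounts for the lower number of compound 3.

Still open, on these data alone, is whether the hydroxyl or the saturated open chain carries the step from allyl; a plain butyl group, a 2-methoxybutyl group or a 2-aminobutyl group on the sulfur would separate these readings. Also open, as far as these compounds go, is how far the result holds along the chain, which a shorter 2-hydroxyethyl group and a longer 2-hydroxyhexyl group on the sulfur would test against the 2-hydroxybutyl of compound 3.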